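Ester to thioester at the carbonyl of compound 2

This account rests on a few compounds, and the source may have more. Where it says the series, first, only, none or still open, it means among the compounds named here.

Compound 2 `C/C=C/COC(=O)/C=C(C)/C=C/CC(C)CCCC(C)(C)OC` stands highest of the two numbers in a physicochemical assay for lipophilicity; on this read-out higher numbers stand for higher lipophilicity and lower numbers for lower lipophilicity; compound 1 `C#CCCOC(=O)/C=C(C)/C=C/CC(C)CCCC(C)(C)OC` gives 5.2, and compound 2 gives 6.07. For the measured compounds named here, the only measured step is a number 0.87 log units higher from compound 1 to compound 2 (beyond the scatter). Compound 3 `C#CCSC(=O)/C=C(C)/C=C/CC(C)CCCC(C)(C)OC` differs from compound 2 by propargylsulfanyl in place of (but-2-en-1-yl)oxy on a carbonyl carbon. Going by the values given here, this partly reverses that step, with the propargyl returning, while the oxygen-to-sulfur exchange has no measured precedent here. Compound 3 is therefore expected to land somewhat below compound 2 in this assay, a step of a number 0.37 log units lower from compound 2 to compound 3 (beyond the scatter), with the estimate for compound 3 being 5.7, ranging from 5.1 to 6.3.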

Compound 3, partition coefficient: 5.9
Compound 3: middle estimate off by 0.20 log units, on the low side; low and high end bracket the measured number.
By their numbers in this assay, from the lowest: compound 1; then compounds 3 and 2 (each within the scatter of the next).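

In this assay the sulfur-linked propargylsulfanyl on the carbonyl carbon does not separate from (but-2-en-1-yl)oxy (a number 0.17 log units lower from compound 2 to compound 3 (within the scatter)), yet it does separate from (but-3-yn-1-yl)oxy (a number 0.70 log units higher from compound 1 to compound 3 (beyond the scatter)). A triple bond in this group therefore does not by itself go with the low number of compound 1. No available evidence bears on these numbers.

On these data alone, both steps change the linking atom and the chain together, so the share of sulfur alone stays open. Also open, as far as these compounds go, is how an amide nitrogen link or a longer chain would read on this carbonyl carbon.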